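Methyl for hydrogen on an aromatic carbon: two steps

A few compounds are considered here, and "the series" means these few. Any claim that something is new, unique, unknown or untested is made for them only; others in the source may bear on it.

Measured compounds in a functional assay on PC-3 cells (Homo sapiens) for cytotoxicity, read by WST assay, with a stated time of 72 h; on this read-out lower numbers stand for stronger inhibition and higher numbers for weaker inhibition:
compound 1 `O=C1Nc2c(ccc(F)c2F)C1(c1ccccc1)c1ccc(O)cc1`: 8.9 nM
compound 2 `Cc1ccc(C2(c3ccc(O)cc3)C(=O)Nc3c2ccc(F)c3F)cc1`: 0.8 nM
compound 3 `O=C1Nc2ccccc2C1(c1ccc(O)cc1)C1CCCCCC1`: only a limit

Compound 3 gives > 1000 nM in this assay, a limit of the assay and not a number; this is the limit of > 1000 nM in this assay, at which 1 of the 3 values shown sits.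

The change from compound 1 to compound 2 is methyl in place of hydrogen on an aromatic carbon. In this assay it made an 11-fold lower number from compound 1 to compound 2 (1.05 log units; beyond the scatter).

Compound 4 `Cc1cccc2c1NC(=O)C2(c1ccc(O)cc1)C1CCCCCC1` is not yet measured; it differs from compound 3 by methyl in place of hydrogen on an aromatic carbon. This is the same kind of change, not the same: in compound 2 the methyl sits para to a large group, while in compound 4 it sits on a ring that is part of a fused or bridged system of two rings, ortho to a fused ring and meta to a fused ring. The difference between the cores of compound 1 and compound 3 is not broken down here.

For compound 4 the step expected in this assay is a step that the limit leaves unreadable from compound 3 to compound 4. This rests on compound 3 standing at a limit, > 1000 nM, so no number anchors the start, and on the measured step having been made at a different place. The estimate for compound 4 in this assay is 1500 nM, expected between 300 nM and 6000 nM.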

Compound 4, half-maximal inhibitory concentration: > 1000 nM
Compound 4 gave a limit, no number; the forecaster's own chance of this, stated with the estimate: 60%; the middle value does not contradict the limit.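

In this assay compound 3 and compound 4 each stand at a limit and not a number, so no step can be read between them: the limit of > 1000 nM in this assay, at which 2 of the 4 values shown sit.

The compounds shown leave open whether methyl in place of hydrogen on an aromatic carbon changes the read-out at all on the core of compound 3.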